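The source may report more compounds than this note shows. Statements on the series, on what has been measured and on what is new or still open speak of the compounds shown alone.

Measured compounds:
compound 1, `CN(C[C@H]1Cc2c(cccc2N2CCN(Cc3ccccn3)CC2)CN1)[C@H]1CCCc2cccnc21`: > 30000 nM
compound 2, `CN(C[C@H]1Cc2c(cccc2N2C[C@H]3C[C@@H]2CN3)CN1)[C@H]1CCCc2cccnc21`: > 30000 nM

In a functional assay on CCRF-CEM cells for agonist activity at C-X-C chemokine receptor type 4 (Homo sapiens), read by calcium flux, with a stated time of 25 min (a lower number here means that less compound is needed, a higher number that more compound is needed for the effect), compound 1 gives only a limit, > 30000 nM, and not a number. Compound 2 likewise gives only a limit in this assay, > 30000 nM. Among the compounds with values here, both values sit at the limit of > 30000 nM in this assay, at which 2 of the 2 values shown sit; nothing can be said of an order between the two compounds, and no step between measured compounds can be drawn from them. Compound 1 thus stands at the limit of this assay and nowhere else on the scale.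

Compound 3, `CN(C[C@H]1Cc2c(cccc2N2CCNCC2)CN1)[C@H]1CCCc2cccnc21`, is not yet measured. It differs from compound 1 in one place: hydrogen in place of (pyridin-2-yl)methyl on an amine nitrogen in a ring. Within the data shown here, with both measured compounds at the limit, there is no measured step from which the size of this change could be read. The expected step from compound 1 to compound 3 in this assay is a number no higher from compound 1 to compound 3 (the limit leaves the size open), which is taken as none beyond the scatter. Compound 3 is estimated at 30000 nM in this assay, with a range from 5000 nM to 100000 nM, and the readout is expected most likely to be a limit again rather than a number.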

Compound 3, half-maximal effective concentration: > 30000 nM
Compound 3: no number, only a limit; the forecaster's own chance of this, stated with the estimate: 75%; the middle value sits exactly at the limit.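

In this assay compound 3 gives > 30000 nM as a limit and not a number, so the steps to it from compound 1 and compound 2 cannot be read: the limit of > 30000 nM in this assay, at which 3 of the 3 values shown sit.

The compounds shown leave open whether any change on the shared core yields a measurable half-maximal effective concentration in this calcium flux read-out.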